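The compounds below may be only part of what the source reports. "The series", "measured", "known", "first", "only" and "open" are said of these compounds alone.

Compound 1 `CC(=O)Nc1nc(C)nc2cn(-c3ccccc3)nc12`: 25%
Compound 2 `O=C(Nc1nc(-c2ccccc2)nc2cn(-c3ccccc3)nc12)c1ccco1`: 11%
Compound 3 `Cc1nc(N(C(=O)c2ccccc2)C(=O)c2ccccc2)c2nn(-c3ccccc3)cc2n1`: 6%

Three compounds built on one shared core were tested in an assay on CHO cells for displacement of a labelled ligand from adenosine receptor A1 (Homo sapiens), read by scintillation counting, with a stated time of 120 min, tested at 1 uM; on this read-out higher numbers stand for more inhibition at the one concentration tested (going by the name of the read-out) and lower numbers for less inhibition. Compound 1 gives 25%, the highest of the three numbers. Compound 2 is built on the same core but differs from compound 1 in several places. In this assay compound 2 gives 11%. This number lies beyond the scatter below that of compound 1. Compound 3 is again different from compound 1 in several places. In this assay compound 3 gives 6%. This number is the furthest from that of compound 1 and also beyond the scatter. Each of compounds 2 and 3 changes several things at once. Among the compounds with values here, no single structural step between measured compounds can be read off; the two lower numbers only show that the inhibition in this assay is lower for compound 2 and for compound 3 than for compound 1.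

The next compound, compound 4 `Cc1nc(NC(=O)c2cccnc2)c2nn(-c3ccccc3)cc2n1`, keeps everything of compound 1 except one change: pyridin-3-yl in place of methyl on a carbonyl carbon. Acetyl becomes (pyridin-3-yl)carbonyl on the carbonyl carbon that sits on the amide-type nitrogen. Within the data shown here, with no measured pair that isolates this change, the step is expected to be small and downward, staying within the scatter, so that compound 4 is expected to give 18%, in a range from 2% to 38%; this expectation means a step of a number 7 percentage points lower from compound 1 to compound 4 (within the scatter).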

Compound 4, a percentage reported as inhibition, at one concentration (the size of the read-out at that concentration, not a potency): 12%
Compound 4: middle estimate off by 6 percentage points, on the high side; the measured number falls inside the stated range.
By their numbers in this assay, from the lowest: compounds 3, 2 and 4 (each within the scatter of the next); then compound 1.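

In this assay, within the data shown here, pyridin-3-yl in place of methyl on the carbonyl carbon gives a number 13 percentage points lower from compound 1 to compound 4 (beyond the scatter), the first step that can be tied to one place. It shows that the read-out responds to the group on this carbonyl carbon, and that this exchange, which brings in a six-membered aromatic ring with a hetero atom, does not raise inhibition at the one concentration tested. Why the number falls cannot be said, since nothing measured on the compounds bears on this step, which rests on a single pair.

The compounds shown leave open whether the lower number goes with the ring itself or with its ring nitrogen, a question that a plain phenyl on the same carbonyl carbon would address, as would pyridin-2-yl or pyridin-4-yl for the place of that nitrogen. They also leave open how a longer chain such as propyl, or an amine such as dimethylamino, would read on this carbonyl carbon, and so whether any group there gives more inhibition than the methyl of compound 1.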